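The compounds below may be only part of what the source reports. "The series", "measured", "known", "first", "only" and "open" are said of these compounds alone.

Working notes on the series, read in a functional assay on MCF7 cells (Homo sapiens) for antiproliferative activity, read by sulforhodamine B assay, with a stated time of 48 h; on this read-out lower numbers stand for stronger inhibition and higher numbers for weaker inhibition. Compound 1 (`COc1ccc(/C=C/C(=O)c2ccccc2-c2ccc(F)cc2)cc1`) gives 670 nM, compound 2 (`CN(C)c1ccc(/C=C/C(=O)c2ccccc2-c2ccc(F)cc2)cc1`) gives 230 nM and compound 3 (`COc1ccc(/C=C/C(=O)c2ccccc2-c2cccc(F)c2)cc1`) gives 640 nM. Compound 3 therefore stands with compound 1, within the scatter, while compound 2 holds the lowest number of the three.

The next structure is compound 4 (`COc1ccc(/C=C/C(=O)c2ccccc2-c2cccnc2)cc1`), with pyridin-3-yl in place of 3-fluorophenyl on an aromatic carbon, ortho to a large group: pyridin-3-yl in place of 3-fluorophenyl on an aromatic carbon.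

The closest evidence is a 1.0-fold lower number from compound 1 to compound 3 (0.02 log units; within the scatter), a change of the same aryl group that stays within the scatter. The other measured step, a 2.9-fold lower number from compound 1 to compound 2 (0.46 log units; beyond the scatter), is dimethylamino in place of methoxy, a change at a different place, so it bears on this question only weakly. Among the measured compounds shown here, no measured compound carries a pyridinyl group, so the range must stay wide.

No step beyond the scatter is expected in this assay. The estimated step is a 1.1-fold higher number from compound 3 to compound 4 (0.04 log units; within the scatter). For compound 4 the expected value is 700 nM, with an estimated range from 270 nM to 1900 nM.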

Compound 4, half-maximal inhibitory concentration: 830 nM
Estimate against measurement, compound 4: 1.2-fold (0.07 log units) below, and the stated range covers the measured number.
By their numbers in this assay, from the lowest: compound 2; then compounds 3, 1 and 4 (each within the scatter of the next).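

Among the compounds shown here, at this place, on an aromatic carbon ortho to a large group, pyridin-3-yl is the only group so far with a ring hetero atom and a hydrogen-bond acceptor, and in this assay it stays level with both fluorophenyl groups (a 1.3-fold higher number from compound 3 to compound 4 (0.11 log units; within the scatter); a 1.2-fold higher number from compound 1 to compound 4 (0.09 log units; within the scatter)). Exchanging the carbon-only aryl ring for one with a ring nitrogen therefore gives no step beyond the scatter, which extends the earlier finding, limited to moving the fluorine, to a change of the ring itself. Nothing measured here accounts for this result.

For the compounds shown here, it remains open whether pyridin-3-yl would hold this level alongside the dimethylamino group of compound 2, the only change so far with a step beyond the scatter. Also open, as far as these compounds go, is whether a saturated amine such as piperidin-4-yl or a carboxylic acid on the aryl ring would shift the number at this place.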